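The compounds below may be only part of what the source reports. "The series", "measured", "known", "first", "only" and "open" are said of these compounds alone.

Measured in an ADME assay on MDCK cells (Canis lupus familiaris) for cytotoxicity, read by MTT assay, with a stated time of 24 h; on this read-out higher numbers stand for lower toxicity in this test and lower numbers for higher toxicity in this test:
- Compound 1 `N#CCCN(Cc1cccs1)S(=O)(=O)c1ccc(C#N)cc1`: > 201000 nM
- Compound 2 `N#CCCN(Cc1cccs1)S(=O)(=O)c1ccc(C(F)(F)F)cc1`: > 178000 nM

Compound 2 gives > 178000 nM in this assay, which is a limit and not a number. Compound 1 gives > 201000 nM, likewise a limit. So compound 2 has no exact position, and neither compound has yet given a measured number in this assay.

The next compound, compound 3 `N#CCCN(Cc1cccs1)S(=O)(=O)c1ccc([N+](=O)[O-])cc1`, carries nitro in place of trifluoromethyl on an aromatic carbon, on a six-membered aromatic ring of carbon only: nitro in place of trifluoromethyl on an aromatic carbon.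

Going by the values given here, only one measured step bears on this change, namely a step that the two limits leave unreadable from compound 1 to compound 2, with trifluoromethyl in place of cyano at the same place. It offers no size to carry over, as the limit of > 178000 nM in this assay, at which 1 of the 2 values shown sits, and the limit of > 201000 nM in this assay, at which 1 of the 2 values shown sits, show. No step beyond the scatter is therefore expected, and compound 3 will most likely also return only a limit. The expected change is a step that the limit leaves unreadable from compound 2 to compound 3. For compound 3 the estimated value is 180000 nM, with an expected range from 70000 nM to 300000 nM.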

Compound 3, half-maximal cytotoxic concentration: > 189000 nM
Compound 3: only a limit was reported; the forecaster's own chance of this, stated with the estimate: 70%; at least 1.0-fold (0.02 log units) between middle value and limit.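

In this assay compound 3 gives > 189000 nM, which is a limit and not a number. Going by these compounds alone, with compound 1, compound 2 and compound 3 all standing as limits, no step among them can be read. The compounds shown leave open whether cyano, trifluoromethyl and nitro on the shared core differ at all in half-maximal cytotoxic concentration.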